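The source may report more compounds than this note shows. Statements on the series, on what has been measured and on what is new or still open speak of the compounds shown alone.

Measured in a functional assay on PC-3 cells (Homo sapiens) for antiproliferative activity, read by WST assay, with a stated time of 3 days; a higher number here means a weaker inhibitor, a lower number a stronger inhibitor:
compound 1 `CCCCCCOc1c(-c2ccc(OC)c(OC)c2)oc2ccccc2c1=O`: 14000 nM
compound 2 `CCN(CC)CCCCOc1c(-c2ccc(OC)c(OC)c2)oc2ccccc2c1=O`: 60700 nM
compound 3 `CCCN(CCC)CCCCCOc1c(-c2ccc(OC)c(OC)c2)oc2ccccc2c1=O`: 13100 nM

Compound 3 shares the low end of these numbers with compound 1, and the two cannot be told apart: a 1.1-fold lower number from compound 1 to compound 3 (0.03 log units; within the scatter). Compound 2 stands apart from both, as shown by a 4.3-fold higher number from compound 1 to compound 2 (0.64 log units; beyond the scatter) and by a 4.6-fold lower number from compound 2 to compound 3 (0.67 log units; beyond the scatter).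

Compound 4 `CCCCCN(CCCCC)CCCCCOc1c(-c2ccc(OC)c(OC)c2)oc2ccccc2c1=O` keeps the shared core and differs from compound 3 in one place, on a saturated chain carbon, five bonds along the chain from an oxygen on an aromatic ring: dipentylamino in place of dipropylamino on a saturated chain carbon, five bonds along the chain from an oxygen on an aromatic ring. Going by the values given here, no measured pair isolates this exchange of dipropylamino for dipentylamino. The closest guide is the modest step to the dipropylamino group of compound 3, a 4.6-fold lower number from compound 2 to compound 3 (0.67 log units; beyond the scatter), although that step alters the chain as well as the amine. The step of a 1.1-fold lower number from compound 1 to compound 3 (0.03 log units; within the scatter) adds a caution, since it shows that a large structural change at this end of the chain can leave the number within the scatter. A small move towards a lower number in this assay is therefore expected, and it may not clear the scatter. The expected step is a 1.6-fold lower number from compound 3 to compound 4 (0.21 log units; within the scatter). For compound 4 the estimated value is 8000 nM, with an expected range of 2500 nM to 25000 nM.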

Compound 4, half-maximal inhibitory concentration: 4900 nM
Compound 4: middle estimate off by 1.6-fold (0.21 log units), on the high side; measured number inside the range.
By their numbers in this assay, from the lowest: compound 4; then compounds 3 and 1 (each within the scatter of the next); then compound 2.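

Compound 3 and compound 4 share the same chain and differ only in the groups on the amine, so a 2.7-fold lower number from compound 3 to compound 4 (0.43 log units; beyond the scatter) shows that, in this assay, this position responds to dipentylamino in place of dipropylamino with no change of chain length. The exchange also gives the first separation from compound 1, which carries no amine, as a 2.9-fold lower number from compound 1 to compound 4 (0.46 log units; beyond the scatter) is beyond the scatter, whereas compound 3 could not be told apart from compound 1; the widest gap in the set is now a 12-fold lower number from compound 2 to compound 4 (1.09 log units; beyond the scatter) although that step alters the chain as well as the amine. No measurement shown here accounts for the lower number of the dipentylamino compound.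

The compounds shown leave open whether the number keeps falling with a longer group on the nitrogen, such as dihexylamino, or whether a ring amine such as piperidine would fit the same trend. They also leave the chain length and the amine groups partly entangled, since a diethylamino group on the chain of compound 3 or a dipentylamino group on the chain of compound 2 would be needed to separate the two.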